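A few compounds are considered here, and "the series" means these few. Any claim that something is new, unique, unknown or untested is made for them only; others in the source may bear on it.

Two compounds from this study share one core and differ in the groups around it. Compound 1, `Clc1ccc(-c2cc(-c3ccc(Cl)o3)cc(-c3ccsc3)n2)cc1`, gives 5.2% in an assay on isolated protein for inhibition of DNA topoisomerase 1 (Homo sapiens), tested at 20 uM; on this read-out lower numbers stand for a weaker effect and higher numbers for a stronger effect at the one concentration tested. Compound 2, `Cc1ccc(-c2cc(-c3ccc(Cl)o3)cc(-c3cccs3)n2)cc1`, gives 9.3% in this assay. The two numbers lie within the scatter of each other, so neither compound can be set apart from the other on this read-out, and both sit at the weak end of the scale. Among the measured compounds shown here, no pair of measured compounds differs in a single place, so nothing in the data tells how one change alone shifts the number.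

Compound 3, `Clc1ccc(-c2cc(-c3ccc(Cl)o3)cc(-c3cccs3)n2)cc1`, is the next compound to be measured. It differs from compound 2 by chloro in place of methyl on an aromatic carbon. Both measured compounds give small numbers within the scatter of one another, and no comparable single change has been measured. A shift beyond the scatter is not expected in this assay for this change. The estimated step is a number 2.3 percentage points lower from compound 2 to compound 3 (within the scatter), a movement that stays inside the scatter. Compound 3 is thus expected to give about 7% in this assay, with a range from 0% to 18%.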

Compound 3, a percentage reported as inhibition, at one concentration (the size of the read-out at that concentration, not a potency): 6.3%
Beside the measured number, compound 3's estimate is 0.7 percentage points above it, and the stated range covers the measured number.
By their numbers in this assay, from the lowest: compounds 1, 3 and 2 (each within the scatter of the next).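

Among the compounds shown here, compound 3 gives the first comparisons in this assay between compounds that differ in one place. On the six-membered aromatic ring of carbon only, para to a large group, going from 4-methylphenyl to 4-chlorophenyl amounts to a number 3 percentage points lower from compound 2 to compound 3 (within the scatter) and so cannot be told apart from repeat measurement, which means that this position, for these two small groups, shows no readable effect on the number. The second change, thiophen-2-yl in place of thiophen-3-yl, gives a number 1.1 percentage points higher from compound 1 to compound 3 (within the scatter) and likewise shows no readable effect, and no measurement at hand speaks to why either change leaves the read-out unmoved.

On these data alone, with all three compounds at the weak end of the scale, it remains open whether any group at the para place, such as an amine, a carboxylic acid or a longer chain in place of chloro, would move the number beyond the scatter. As far as these compounds go, it also remains open whether an amine or a hydroxyl on the thiophene, or a change elsewhere on the shared core, would bring a stronger effect in this assay at all.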